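Trifluoromethyl for methyl on a quinolinecarboxamide core

The source may hold more compounds than are shown below. What is called first, only, known or untested is meant among the compounds shown, and "the series" means these compounds.

Of the compounds shown here, three of a shared core have been measured in a functional assay on A-375 cells (Homo sapiens) for antiproliferative activity, read by MTT assay, with a stated time of 24 h, tested at 33.33 ug/mL; on this read-out lower numbers stand for a weaker effect and higher numbers for a stronger effect at the one concentration tested. Compound 1 `Cc1ccc2nc(C(=O)Nc3c(F)cc(-c4cccc(F)c4)cc3F)c(C)c(O)c2c1` gives 26.5%, compound 2 `CCOc1ccc2nc(C(=O)Nc3c(F)cc(-c4cccc(F)c4)cc3F)c(C)c(O)c2c1` gives 16.3%, and compound 3 `Cc1ccc2nc(C(=O)Nc3c(F)cc(-c4cccc(F)c4)cc3F)c(C)c(C(=O)O)c2c1` gives 26.3%. Compound 3 stands second highest of the three numbers, with compound 1 nearest and compound 2 furthest, both within the scatter of it. The step of a number 10.2 percentage points lower from compound 1 to compound 2 (beyond the scatter) was a modest drop, while the step of a number 0.2 percentage points lower from compound 1 to compound 3 (within the scatter) stayed within the scatter.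

Compound 4 `Cc1c(C(=O)Nc2c(F)cc(-c3cccc(F)c3)cc2F)nc2ccc(C(F)(F)F)cc2c1C(=O)O` differs from compound 3 at one place: trifluoromethyl in place of methyl on an aromatic carbon. Among the compounds with values here, no measured step changes the methyl at this place into trifluoromethyl. Within the data shown here, the only step at the same place, a number 10.2 percentage points lower from compound 1 to compound 2 (beyond the scatter), lowered this assay modestly, and the one step elsewhere on the core left it unchanged. A small step at most is therefore expected, so compound 4 is estimated to give 23%, between 9% and 37%, which means an expected step of a number 3.3 percentage points lower from compound 3 to compound 4 (within the scatter).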

Compound 4, a percentage reported as inhibition, at one concentration (the size of the read-out at that concentration, not a potency): 51%
The estimate for compound 4 lay 28 percentage points below the measured number; measured number above the stated range.
By their numbers in this assay, from the lowest: compounds 2, 3 and 1 (each within the scatter of the next, the first and the last beyond it); then compound 4.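

The step of a number 24.7 percentage points higher from compound 3 to compound 4 (beyond the scatter) in this assay is the first shown at this position that raises the number, whereas the only earlier step here, a number 10.2 percentage points lower from compound 1 to compound 2 (beyond the scatter), lowered it. This aromatic carbon therefore does more than tolerate change: ethoxy and trifluoromethyl move the number in opposite directions, although those two steps start from compounds that differ in carrying hydroxy or carboxy elsewhere on the shared core. Nothing measured here accounts for the rise.

The compounds shown leave open whether trifluoromethyl would raise the number equally with hydroxy in place of carboxy, as in compound 1. They also leave open whether a chlorine atom, a methoxy group or a longer fluorinated chain at this position would behave like trifluoromethyl or like ethoxy.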